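Working notes: from compound 3 to compound 4

The compounds below may be only part of what the source reports. "The series", "measured", "known", "first", "only" and "open" are said of these compounds alone.

- compound 1 `CC/C=C\C[C@H]1C(=O)C=C[C@H]1CC(=O)OCCO` gives 161 uM
- compound 2 `CC/C=C\C[C@H]1C(=O)C=C[C@H]1CC(=O)OCCOCCOC` gives 161 uM
- compound 3 `CC/C=C\C[C@H]1C(=O)C=C[C@H]1CC(=O)OC(C)(C)C` gives 33 uM

In an ADME assay on RAW264.7 cells (Mus musculus) for cytotoxicity, read by MTT assay, with a stated time of 24 h (a lower number here means that less compound is tolerated, a higher number that more compound is tolerated), compound 3 holds the lowest of the three numbers (33 uM) and lies beyond the scatter from both other compounds. Two measured steps reach it: a 4.9-fold lower number from compound 1 to compound 3 (0.69 log units; beyond the scatter) and a 4.9-fold lower number from compound 2 to compound 3 (0.69 log units; beyond the scatter) (tert-butyl in place of 2-hydroxyethyl and of 2-(2-methoxyethoxy)ethyl). The remaining step shows no change at the digits printed from compound 1 to compound 2 (within the scatter) (the two longer groups give the same number).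

The next compound is compound 4 `CC/C=C\C[C@H]1C(=O)C=C[C@H]1CC(=O)OC1CCCCC1`. The change is cyclohexyl in place of tert-butyl on an oxygen next to a carbonyl group. Among the compounds with values here, no measured step involves cyclohexyl, so the evidence is indirect. The only large moves so far, a 4.9-fold lower number from compound 1 to compound 3 (0.69 log units; beyond the scatter) and a 4.9-fold lower number from compound 2 to compound 3 (0.69 log units; beyond the scatter) (both modest), lead to tert-butyl from the groups that contain oxygen. Cyclohexyl, like tert-butyl, is built of carbon only, so compound 4 is expected to stay close to compound 3 and not to return towards compound 1. The expected result is a 1.1-fold lower number from compound 3 to compound 4 (0.04 log units; within the scatter) (no step beyond the scatter is expected in this assay). The estimate for compound 4 is 30 uM (12 uM to 75 uM).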

Compound 4, half-maximal toxic concentration: 31 uM
For compound 4 the middle estimate is 1.0-fold (0.01 log units) below the measured one; measured number inside the range.
By their numbers in this assay, from the lowest: compounds 4 and 3 (each within the scatter of the next); then compounds 1 and 2 (each within the scatter of the next).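

Working notes after compound 4: in this assay, a second group built of carbon only on the oxygen next to a carbonyl group gives a number indistinguishable from that of tert-butyl (a 1.1-fold lower number from compound 3 to compound 4 (0.03 log units; within the scatter)), so replacing tert-butyl with cyclohexyl, which adds a six-membered ring of carbon only, produces no readable shift. Compared with the two groups that contain oxygen, cyclohexyl gives the same kind of drop as tert-butyl (a 5.2-fold lower number from compound 2 to compound 4 (0.72 log units; beyond the scatter); a 5.2-fold lower number from compound 1 to compound 4 (0.72 log units; beyond the scatter)), so the lower numbers no longer rest on tert-butyl alone, and none of the four compounds goes against this split. No measurement at hand bears on what lies behind the split.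

The compounds shown leave open how other groups on this oxygen would read, such as benzyl, a straight hexyl chain or a chain that ends in an amine, and whether a free carboxylic acid would sit with compound 1 and compound 2 or apart from them. From the compounds shown here alone, all four compounds also share the same core, so the effect of any change outside this position remains unknown.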